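The compounds below may be only part of what the source reports. "The series", "measured", "known", "first", "only" and "open" are said of these compounds alone.

Measured in an ADME assay on HMEC-1 cells (Homo sapiens) for cytotoxicity, read by MTT assay, with a stated time of 72 h; a higher number here means that more compound is tolerated, a lower number that less compound is tolerated:
compound 1 `Cc1c(CN2CCCC2)cc(-c2ccccc2)n1Nc1ccnc2cc(Cl)ccc12`: 12900 nM
compound 2 `Cc1c(CN2CCCC2)cc(-c2ccc(F)cc2)n1Nc1ccnc2cc(Cl)ccc12`: 10100 nM
compound 3 `CCN(CC)Cc1cc(-c2ccc(C)cc2)n(Nc2ccnc3cc(Cl)ccc23)c1C`: 7050 nM

Compound 3 gives the lowest of the three numbers, but its gaps to compound 2 and to compound 1 both fall within the scatter, so the three compounds are not separated in this assay. Compound 4 `Cc1ccc(-c2cc(CN3CCCC3)c(C)n2Nc2ccnc3cc(Cl)ccc23)cc1` differs from compound 3 by pyrrolidin-1-yl in place of diethylamino on a saturated chain carbon bound to an aromatic carbon. For the measured compounds named here, the only recorded step, a 1.3-fold lower number from compound 1 to compound 2 (0.11 log units; within the scatter), concerns a different position and lies within the scatter. Going by the values given here, no measured step touches the amine itself; compound 1 and compound 2, which carry pyrrolidin-1-yl, sit within the scatter of compound 3. For compound 4 a step of a 1.3-fold higher number from compound 3 to compound 4 (0.11 log units; within the scatter) is therefore expected, that is, none beyond the scatter. Compound 4 is estimated at 9000 nM, with a range of 4500 nM to 18000 nM.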

Compound 4, half-maximal cytotoxic concentration: 7150 nM
Compound 4: middle estimate off by 1.3-fold (0.10 log units), on the high side; the measured number falls inside the stated range.
By their numbers in this assay, from the lowest: compounds 3, 4, 2 and 1 (each within the scatter of the next).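

In this assay, the amine now has a direct step: pyrrolidin-1-yl in place of diethylamino gives a 1.0-fold higher number from compound 3 to compound 4 (0.01 log units; within the scatter) and stays within the scatter. On the aromatic carbon, methyl in place of fluoro gives a 1.4-fold lower number from compound 2 to compound 4 (0.15 log units; within the scatter), and methyl in place of hydrogen gives a 1.8-fold lower number from compound 1 to compound 4 (0.26 log units; within the scatter), so neither site separates these compounds. The data offer no evidence that could explain these results.

Open, from the compounds shown here alone, is whether morpholine in place of the amine, or a longer chain carrying it, would give a step beyond the scatter. The same question holds for methoxy or trifluoromethyl on the aromatic carbon.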